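Ethoxy in place of methylamino on the carbonyl of compound 2

The source may hold more compounds than are shown below. What is called first, only, known or untested is meant among the compounds shown, and "the series" means these compounds.

The measured compounds:
compound 1, `CCn1c(CNc2ccccc2)nnc1SCC(=O)Nc1ccc(C(C)=O)cc1`, > 1000 nM
compound 2, `CCn1c(CNc2ccccc2)nnc1SCC(=O)Nc1ccc(C(=O)NC)cc1`, > 1000 nM
compound 3, `CCn1c(CNc2ccccc2)nnc1SCc1nc2cc(OC(F)(F)F)ccc2o1`, 100 nM

In an assay on isolated protein for inhibition of long-chain fatty acid transport protein 1 (Homo sapiens) (on this read-out lower numbers stand for stronger inhibition and higher numbers for weaker inhibition), compound 1 gives > 1000 nM, which is a limit of the assay and not a number. In this assay compound 2 likewise gives > 1000 nM, again a limit rather than a number. Compound 3 gives 100 nM in this assay. Among the compounds with values here, the only single-point step among them, a step that the two limits leave unreadable from compound 1 to compound 2, has no readable size, since both compounds share (the limit of > 1000 nM in this assay, at which 2 of the 3 values shown sit).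

Compound 4, `CCOC(=O)c1ccc(NC(=O)CSc2nnc(CNc3ccccc3)n2CC)cc1`, has not yet been measured. It differs from compound 2 by ethoxy in place of methylamino on a carbonyl carbon. Within the data shown here, no measured step bears directly on this change, and the one neighbouring step, a step that the two limits leave unreadable from compound 1 to compound 2, is unreadable. With two exchanges at the same carbonyl carbon both leaving the value at the limit, compound 4 is expected to remain weak, with an estimated step that the limit leaves unreadable from compound 2 to compound 4 that amounts to nothing beyond the scatter. Compound 4 is therefore estimated at 2000 nM, expected to lie between 600 nM and 7000 nM.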

Compound 4, half-maximal inhibitory concentration: 330 nM
Beside the measured number, compound 4's estimate is 6.1-fold (0.78 log units) above it; the whole stated range lies above it.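

In this assay, ethoxy on the carbonyl carbon gives an at least 3.0-fold lower number from compound 2 to compound 4 (0.48 log units; beyond the scatter), and measured against methyl at the same carbon it gives an at least 3.0-fold lower number from compound 1 to compound 4 (0.48 log units; beyond the scatter). Within the data shown here, this shows that the group on this carbonyl carbon can move the value, which the earlier pair could not show, its one step being unreadable. Both sizes are lower bounds only, as each step starts from a limit and not a number: the limit of > 1000 nM in this assay, at which 2 of the 4 values shown sit.

What the compounds shown leave open is whether the change follows from the ethoxy chain itself or from the loss of the amide hydrogen, and how a methoxy, a propoxy or a carboxylic acid on this carbonyl carbon would read. Compound 3 differs from compound 4 in more than one place, so it cannot settle how far this part of the molecule can be taken.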